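Inverting Two Stereocentres of Compound 1

The compounds below may be only part of what the source reports. "The series", "measured", "known", "first", "only" and "open" are said of these compounds alone.

Measured in a functional assay on A2780 cells (Homo sapiens) for cytotoxicity, read by MTT assay, with a stated time of 24 h; a higher number here means a weaker inhibitor, a lower number a stronger inhibitor:
- compound 1 `CCCCC[C@@H](C[C@@H](O)C[C@@H]1CC=CC(=O)O1)OC`: 49400 nM
- compound 2 `CCCCC[C@@H](CCC[C@@H]1CC=CC(=O)O1)OC`: 14900 nM
- compound 3 `CCCCC[C@H](C[C@H](O)C[C@@H]1CC=CC(=O)O1)OC`: 22900 nM

Of these three, compound 1 has the highest number, and both of its steps to the others lie beyond the usual scatter. Compound 4 `CCCCC[C@@H](C[C@H](O)C[C@H]1CC=CC(=O)O1)OC` has not yet been measured. Its relation to compound 1 is this: the two compounds have the same atoms and bonds and differ only in configuration as drawn: 2 of 3 stereo elements differ; a stereocentre at a saturated chain carbon is drawn R in compound 1 and S in compound 4; a stereocentre at a saturated ring carbon is drawn S in compound 1 and R in compound 4.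

The closest guide is a 2.2-fold lower number from compound 1 to compound 3 (0.33 log units; beyond the scatter), which also changes two stereocentres. That step is tied to configuration by the fact that compounds 1 and 3 differ only in the configuration as drawn. The guide is imperfect, since both centres that differ there are chain carbons, whereas compound 4 also differs at a ring carbon. The other step, a 3.3-fold lower number from compound 1 to compound 2 (0.52 log units; beyond the scatter), places hydrogen where hydroxy stood. Compound 4 keeps its hydroxy group, so that step only indicates a typical size of change.

A modest step towards a lower number in this assay is therefore expected, although no real change would not be surprising. The expected step is a 2.1-fold lower number from compound 1 to compound 4 (0.31 log units; beyond the scatter). For compound 4 the estimated value is 24000 nM, with an expected range of 10000 nM to 60000 nM.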

Compound 4, half-maximal inhibitory concentration: 53700 nM
Compound 4: the middle estimate sits 2.2-fold (0.35 log units) below what was measured; the range from low to high includes it.
By their numbers in this assay, from the lowest: compounds 2 and 3 (each within the scatter of the next); then compounds 1 and 4 (each within the scatter of the next).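

In this assay, inverting a saturated ring carbon together with a saturated chain carbon gives a 1.1-fold higher number from compound 1 to compound 4 (0.04 log units; within the scatter), so this pair of inversions does not separate the two compounds. The counting of inverted centres therefore predicts little: compound 3 and compound 4 each differ from compound 1 at two stereocentres, yet the step between them is a 2.3-fold higher number from compound 3 to compound 4 (0.37 log units; beyond the scatter), which shows that it matters which two centres are inverted. That step can be tied to the three-dimensional arrangement alone: the fact that compounds 3 and 4 differ only in the configuration as drawn

The compounds shown invert these centres only in pairs, so the share of each single centre stays open. Also open, on these data alone, is how an amine in place of the hydroxy group, or a longer chain in place of the pentyl end, would read in this assay.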